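A 3,5-dimethoxyphenyl group replaces 2,4-dichlorophenyl

The compounds below may be only part of what the source reports. "The series", "measured", "known", "first", "only" and "open" are said of these compounds alone.

In a functional assay on CCRF-CEM cells (Homo sapiens) for antiproliferative activity, with a stated time of 72 h (a lower number here means a stronger inhibitor, a higher number a weaker inhibitor), compound 1 (`OC[C@H]1O[C@@H](n2cnc3c(NCc4ccc(F)cc4)ncnc32)[C@H](O)[C@@H]1O`) gives 1250 nM as its half-maximal inhibitory concentration. Compound 2 (`Cc1ccc(CNc2ncnc3c2ncn3[C@@H]2O[C@H](CO)[C@@H](O)[C@H]2O)cc1`) is known only as a limit of the assay (> 166000 nM). Compound 3 (`OC[C@H]1O[C@@H](n2cnc3c(NCc4ccc(Cl)cc4Cl)ncnc32)[C@H](O)[C@@H]1O`) stands higher of the two actual numbers (86700 nM). Compound 4 (`COc1cc(CNc2ncnc3c2ncn3[C@@H]2O[C@H](CO)[C@@H](O)[C@H]2O)cc(OC)c1`) has 3,5-dimethoxyphenyl in place of 2,4-dichlorophenyl on a saturated chain carbon bound to a nitrogen on an aromatic ring. Two large steps bear on this (an at least 130-fold higher number from compound 1 to compound 2 (2.12 log units; beyond the scatter)) and (a 69-fold higher number from compound 1 to compound 3 (1.84 log units; beyond the scatter)), and both leave the aromatic group of compound 1, which compound 4 also lacks. Compound 4 is therefore expected to stay near compound 3, with no step beyond the scatter (a 1.4-fold lower number from compound 3 to compound 4 (0.16 log units; within the scatter)). For compound 4 the estimated value is 60000 nM (expected range 10000 nM to 160000 nM).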

Compound 4, half-maximal inhibitory concentration: > 166000 nM
Compound 4: a limit, no number; the forecaster's own chance of this, stated with the estimate: 35%; middle value at least 2.7-fold (0.44 log units) away from the limit.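

Compound 4 is known only as a limit, so a second group at this position, after 4-methylphenyl, gives no number: the limit of > 166000 nM in this assay, at which 2 of the 4 values shown sit.

Against 2,4-dichlorophenyl, the change gives an at least 1.9-fold higher number from compound 3 to compound 4 (0.28 log units; that floor lies within the scatter), so it does not separate compound 4 from compound 3. Against 4-fluorophenyl, it gives an at least 130-fold higher number from compound 1 to compound 4 (2.12 log units; beyond the scatter), and the step between compound 2 and compound 4 cannot be read.

The compounds shown leave open whether unsubstituted phenyl or 4-chlorophenyl at this place would stay near compound 1 in this assay. They also leave open how an amine on the ring would read.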